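The source may hold more compounds than are shown below. What is called first, only, known or untested is meant among the compounds shown, and "the series" means these compounds.

In a functional assay on HOP-62 cells (Homo sapiens) for inhibition, read by sulforhodamine B assay (on this read-out lower numbers stand for stronger inhibition of growth and higher numbers for weaker inhibition of growth), compound 3 (`Cc1ccc2[nH]c(-c3ccc(-c4ccc(-c5ccc(C(F)(F)F)cc5)cc4)cc3)nc2c1`) reads 24200 nM and has the highest number of the three measured compounds. Compound 1 (`Cc1ccc2[nH]c(-c3ccc(-c4ccc(-c5ccc(N(C)C)cc5)cc4)cc3)nc2c1`) gives 4230 nM on the same core, and compound 2 (`Oc1cccc2[nH]c(-c3ccc(-c4ccc(-c5ccc(OC(F)(F)F)cc5)cc4)cc3)nc12`) gives 2270 nM on a different core.

Compound 4 (`Cc1ccc2[nH]c(-c3ccc(-c4ccc(-c5ccc(OC(F)(F)F)cc5)cc4)cc3)nc2c1`) keeps the core of compound 3 and changes one group: trifluoromethoxy in place of trifluoromethyl on an aromatic carbon (trifluoromethoxy in place of trifluoromethyl on an aromatic carbon, para to a large group).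

Among the measured compounds shown here, the one measured step at this place is a 5.7-fold higher number from compound 1 to compound 3 (0.76 log units; beyond the scatter) and it shows that a swap there can move the number beyond the scatter on this core. For the measured compounds named here, no measured step covers trifluoromethoxy on this core. The closest evidence is compound 2, which carries trifluoromethoxy and reads 2270 nM in this assay but has another core, so its value gives only a loose guide. With compound 3 at the top of the measured range and compound 2 well under it, a modest move to a lower number is expected, no larger than about the size of the measured step.

The expected step is a 2.7-fold lower number from compound 3 to compound 4 (0.43 log units; beyond the scatter) in this assay as a working figure. For compound 4 the estimated value is 9000 nM with an expected range from 3000 nM to 25000 nM in this assay for now.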

Compound 4, concentration for 50% growth inhibition: 24200 nM
Compound 4: middle estimate off by 2.7-fold (0.43 log units), on the low side, within the range that was stated.
By their numbers in this assay, from the lowest: compounds 2 and 1 (each within the scatter of the next); then compounds 3 and 4 (each within the scatter of the next).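

In this assay, the change from 4-(trifluoromethyl)phenyl to 4-(trifluoromethoxy)phenyl gives no change at the digits printed from compound 3 to compound 4 (within the scatter), so on this core the two fluorinated groups cannot be told apart at this position, while a 5.7-fold higher number from compound 1 to compound 4 (0.76 log units; beyond the scatter) puts dimethylamino apart from trifluoromethoxy as well as from trifluoromethyl. With trifluoromethoxy held constant, the change in the benzimidazole group gives an 11-fold higher number from compound 2 to compound 4 (1.03 log units; beyond the scatter), which ties the lower value of compound 2 to its 4-hydroxy-1H-benzimidazol-2-yl group and not to trifluoromethoxy alone. No supporting data are available to explain either the flat step between the two fluorinated groups or the steps beyond the scatter.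

From the compounds shown here alone, it remains open whether a primary amine or a carboxylic acid at this position would read with compound 1 or with compound 3 and compound 4. Also open, going by these compounds, is whether the equivalence of trifluoromethyl and trifluoromethoxy holds on the core of compound 2, and whether dimethylamino on that core would read differently from trifluoromethoxy there.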